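A few compounds are considered here, and "the series" means these few. Any claim that something is new, unique, unknown or untested is made for them only; others in the source may bear on it.

Among the compounds with values here, in a functional assay on A549 cells (Homo sapiens) for antiproliferative activity, read by sulforhodamine B assay, with a stated time of 48 h (a higher number here means a weaker inhibitor, a lower number a stronger inhibitor), compound 2 `COc1ccc(C(=O)/C=C\Nc2ccc(-c3nc4cc(OC)c(OC)c(OC)c4s3)cc2C)cc1F` gives 1690 nM, the lowest number of the three compounds measured so far. Compound 3 `COc1ccc(C(=O)/C=C\Nc2ccc(-c3nc4cc(OC)c(OC)c(OC)c4s3)cc2C)cc1[N+](=O)[O-]` gives 9100 nM, and compound 1 `COc1cc(OC)c2sc(-c3ccc(N/C=C\C(=O)c4ccc(OC)c([N+](=O)[O-])c4)c(C)c3)nc2c1` gives 12100 nM. Compound 4 `COc1cc(OC)c2sc(-c3ccc(N/C=C\C(=O)c4ccc(OC)c(F)c4)c(C)c3)nc2c1` has not yet been measured. It differs from compound 2 by hydrogen in place of methoxy on an aromatic carbon.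

The closest measured precedent is the same exchange read in reverse, methoxy in place of hydrogen, which gives a 1.3-fold lower number from compound 1 to compound 3 (0.12 log units; within the scatter). That pair carries nitro, however, whereas compound 2 and compound 4 carry fluoro. The nitro-for-fluoro exchange itself gives a 5.4-fold higher number from compound 2 to compound 3 (0.73 log units; beyond the scatter), so the nitro pair may not carry over exactly. On this evidence, no change beyond the scatter is expected in this assay, though a slight rise would not be surprising. The expected step is a 1.2-fold higher number from compound 2 to compound 4 (0.09 log units; within the scatter). The estimated value for compound 4 is 2100 nM, with an expected range from 900 nM to 5000 nM.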

Compound 4, half-maximal inhibitory concentration: 15300 nM
Compound 4: the middle estimate sits 7.3-fold (0.86 log units) below what was measured; measured number above the stated range.
By their numbers in this assay, from the lowest: compound 2; then compounds 3, 1 and 4 (each within the scatter of the next).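

In this assay, the methoxy that sits ortho to two methoxy groups matters when fluoro is present: hydrogen in its place gives a 9.1-fold higher number from compound 2 to compound 4 (0.96 log units; beyond the scatter), a loss that the nitro pair gave no sign of. The effect of this exchange therefore depends on the group carried elsewhere in the compound: the same change on two cores in this assay, a 1.3-fold lower number (0.12 log units; within the scatter) from compound 1 to compound 3 and a 9.1-fold lower number (0.96 log units; beyond the scatter) from compound 4 to compound 2, 6.8-fold (0.83 log units) apart, beyond the scatter of two such steps

Without this methoxy, fluoro in place of nitro gives a 1.3-fold higher number from compound 1 to compound 4 (0.10 log units; within the scatter), so the lower number seen with fluoro appears only in compound 2, which keeps the methoxy: the same change on two cores in this assay, a 5.4-fold higher number (0.73 log units; beyond the scatter) from compound 2 to compound 3 and a 1.3-fold lower number (0.10 log units; within the scatter) from compound 4 to compound 1, 6.8-fold (0.83 log units) apart, beyond the scatter of two such steps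

The compounds shown leave open whether a longer ether such as ethoxy, or an amine, at this position would hold the number of compound 2. They also leave open whether chloro in place of fluoro would show the same dependence on this methoxy.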